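The compounds below may be only part of what the source reports. "The series", "measured", "known", "first", "only" and "open" are said of these compounds alone.

Of the compounds shown here, three have so far been measured in a functional assay on the whole organism for inhibition, with Rattus norvegicus as the target, with stated times of 1 h and 3.5 h, at a dose of 100 mg/kg by the oral route; a lower number here means less inhibition, a higher number more inhibition at the dose given (going by the name of the read-out). Compound 1 `Nc1nccc(-c2ccccn2)n1` gives 17% in this assay, compound 2 `Nc1nccc(-c2cccnc2)n1` gives 32%, and compound 3 `Cc1ncc(-c2ccccc2)c(C(C)(C)C)n1` gives 22%. Compound 3 stands within the usual scatter of both compound 1 and compound 2, so its number can be set apart from neither of the other two, and the three readings together describe a modest level of inhibition at this dose.

Compound 4 `CC(C)(C)c1nc(NN)ncc1-c1ccccc1` has not yet been measured. It differs from compound 3 in one place: aminoamino in place of methyl on an aromatic carbon. Within the data shown here, no pair of measured compounds shows this kind of exchange, so there is nothing to say how large a shift it might bring in this assay. Among the measured compounds shown here, with no comparable step available, the expectation is a step from compound 3 to compound 4 of about a number 3 percentage points higher from compound 3 to compound 4 (within the scatter), that is, none beyond the scatter. For compound 4 the estimated value in this assay is therefore 25%, with a range from 5% to 50%.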

Compound 4, a percentage reported as inhibition, in the whole organism at one dose (the size of the read-out at that dose, not a potency): < 5%
Compound 4: only a limit was reported; the forecaster's own chance of this, stated with the estimate: 0%; middle value at least 20 percentage points from the limit.
By their numbers in this assay, from the lowest: compounds 1, 3 and 2 (each within the scatter of the next, the first and the last beyond it). At a limit, below all of these: compound 4.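

In this assay compound 4 gives < 5%, which is a limit of the assay and not a number. With aminoamino in place of methyl on the aromatic carbon between two ring nitrogen atoms, the change gives a number at least 17 percentage points lower from compound 3 to compound 4 (beyond the scatter). Among these compounds, the earlier compounds offered no step at a single place, so this is the first sign that inhibition at this dose depends on what sits at this position, and that this exchange takes away the modest inhibition seen with methyl.

This single step cannot separate the loss of methyl from the arrival of the nitrogen atoms and hydrogen-bond donors of aminoamino. On these data alone, it remains open whether a methoxy group, a carboxylic acid or a longer chain such as ethyl at the same position would keep, raise or lose the inhibition.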